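This account rests on a few compounds, and the source may have more. Where it says the series, first, only, none or still open, it means among the compounds named here.

Measured compounds in an assay for inhibition of cathepsin H (Capra hircus), using Lineweaver-Burk analysis; a higher number here means a weaker inhibitor, a lower number a stronger inhibitor:
compound 1 `Clc1ccc(C2CC(c3ccccc3)=NN2)cc1` — 1560 nM
compound 2 `Brc1ccc(C2CC(c3ccccc3)=NN2)cc1` — 5380 nM

Going by the values given here, compound 2 holds the highest of the two numbers in this assay; the nearest is compound 1, and the two are separated by a 3.4-fold higher number from compound 1 to compound 2 (0.54 log units; beyond the scatter), the only measured step. Compound 3 `COc1ccc(C2CC(c3ccccc3)=NN2)cc1` differs from compound 2 by methoxy in place of bromo on an aromatic carbon. Among the compounds with values here, no measured step covers a methoxy group at this position, so the only guide is indirect: the step of a 3.4-fold higher number from compound 1 to compound 2 (0.54 log units; beyond the scatter) shows that chloro in the same place gives a lower number than bromo, and compound 1 with 1560 nM marks where a non-bromo substituent has landed. For compound 3 a step of a 2.7-fold lower number from compound 2 to compound 3 (0.43 log units; beyond the scatter) is therefore expected, toward a lower number, with low confidence. Compound 3 is estimated at 2000 nM, within a range of 700 nM to 6000 nM.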

Compound 3, inhibition constant: 9800 nM
The estimate for compound 3 lay 4.9-fold (0.69 log units) below the measured number, and the stated range ends below it.
By their numbers in this assay, from the lowest: compound 1; then compounds 2 and 3 (each within the scatter of the next).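

In this assay, methoxy in place of bromo gives a 1.8-fold higher number from compound 2 to compound 3 (0.26 log units; within the scatter), so the two groups cannot be told apart at this position, even though methoxy brings a hydrogen-bond acceptor that bromo lacks. Measured against chloro, the same group gives a 6.3-fold higher number from compound 1 to compound 3 (0.80 log units; beyond the scatter) and this places compound 1, the chloro member, apart from both others as the strongest inhibitor of the three. No measurement at hand accounts for this separation.

The compounds shown leave open whether the lower number belongs to chloro alone or would also appear with fluoro or methyl at this position. From the compounds shown here alone, how an amine or a carboxylic acid would behave in the same place also remains unknown, as does the effect of changing the unsubstituted phenyl group on the other side of the shared core.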